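Trimming a side chain at the solubility limit

The source may report more compounds than this note shows. Statements on the series, on what has been measured and on what is new or still open speak of the compounds shown alone.

Measured in a physicochemical assay for solubility, at pH 6.8; a lower number here means a less soluble compound, a higher number a more soluble compound:
Compound 1 `COCCOCCCCc1[nH]c2ccccc2c(=O)c1C`: >= 100000 nM
Compound 2 `Cc1c(COCCCCOCC2(C)COC2)[nH]c2ccccc2c1=O`: >= 100000 nM

Neither entry is an exact reading. Compound 2 gives >= 100000 nM, and that value is a limit of the assay, not a number. Compound 1 gives >= 100000 nM, which is a limit as well. All that can be said so far is summed up as the limit of >= 100000 nM in this assay, at which 2 of the 2 values shown sit. Among the compounds with values here, compound 2 therefore has no exact place on the scale, and no measured step is available to size a structural change.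

Compound 3 `Cc1c(COCCCCO)[nH]c2ccccc2c1=O` has hydrogen in place of (3-methyloxetan-3-yl)methyl on an oxygen on a saturated carbon. Cut one bond further out, the same difference reads (3-methyloxetan-3-yl)methoxy to hydroxy.

The expectation rests on compound 2 with its limit of >= 100000 nM. No step beyond the usual scatter is expected in this assay, in either direction, and the reading will probably again be a limit. The estimated change is a number no higher from compound 2 to compound 3 (the limit leaves the size open). Compound 3 is expected near 100000 nM, with an estimated range from 40000 nM to 200000 nM.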

Compound 3, solubility: >= 100000 nM
Compound 3: only a limit was reported; the forecaster's own chance of this, stated with the estimate: 80%; the middle value lies on the limit itself.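

In this assay compound 3 gives >= 100000 nM, which is a limit of the assay and not a number. Compound 2 also sits at a limit, so no step can be read between compound 2 and compound 3. The compounds shown leave open how their exact solubilities compare, as the data so far amount to a single ceiling: the limit of >= 100000 nM in this assay, at which 3 of the 3 values shown sit.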